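Chloro in place of methyl on the aromatic carbon of compound 3

The source may hold more compounds than are shown below. What is called first, only, known or untested is meant among the compounds shown, and "the series" means these compounds.

Compound 3 `Cc1ccc(S(C)(=O)=O)cc1C#Cc1cc(Cl)ccc1OCC(=O)O` gives 5 nM in an assay on CHO cells for displacement of a labelled ligand from prostaglandin D2 receptor 2 (Homo sapiens), read by scintillation counting (on this read-out higher numbers stand for weaker inhibition and lower numbers for stronger inhibition), the second highest of the three numbers. Compound 1 `CS(=O)(=O)c1ccc(F)c(C#Cc2cc(Cl)ccc2OCC(=O)O)c1` gives 3.3 nM and is nearest; compound 2 `Cc1ccc(S(=O)(=O)N(C)CCN(C)C)cc1C#Cc1cc(Cl)ccc1OCC(=O)O` gives 369 nM and is furthest. The measured steps are a 1.5-fold higher number from compound 1 to compound 3 (0.18 log units; within the scatter) and a 74-fold lower number from compound 2 to compound 3 (1.87 log units; beyond the scatter). Compound 4 `CS(=O)(=O)c1ccc(Cl)c(C#Cc2cc(Cl)ccc2OCC(=O)O)c1` differs from compound 3 by chloro in place of methyl on an aromatic carbon. For the measured compounds named here, only the step from compound 1 bears on it, since it changed the same aromatic carbon, methyl in place of fluoro, and stayed within the scatter; the large step from compound 2 concerns the sulfonyl sulfur and does not apply. For compound 4 in this assay no step beyond the scatter is therefore expected, an estimated step of a 1.3-fold lower number from compound 3 to compound 4 (0.10 log units; within the scatter). Compound 4 is estimated at 4 nM, range 2 nM to 10 nM.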

Compound 4, inhibition constant: 3.5 nM
Compound 4: middle estimate off by 1.1-fold (0.06 log units), on the high side, and the stated range covers the measured number.
By their numbers in this assay, from the lowest: compounds 1, 4 and 3 (each within the scatter of the next); then compound 2.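

At the aromatic carbon para to a methylsulfonyl group, chloro now stands alongside methyl and fluoro. In this assay the new steps are a 1.4-fold lower number from compound 3 to compound 4 (0.15 log units; within the scatter) and a 1.1-fold higher number from compound 1 to compound 4 (0.03 log units; within the scatter); both lie within the scatter, so these three groups cannot be told apart at this position. Nothing at hand accounts for this flat result.

Open, from the compounds shown here alone, is whether an amine, a carboxylic acid or a longer chain on this carbon would stay as flat. Also open, going by these compounds, is whether chloro here would hold its number with (2-(dimethylamino)ethyl)(methyl)amino on the sulfonyl sulfur.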